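Thiadiazole oxime ethers tested on gastric carcinoma cells

The source may hold more compounds than are shown below. What is called first, only, known or untested is meant among the compounds shown, and "the series" means these compounds.

Measured compounds:
compound 1 `Cc1nnsc1CO/N=C/c1c(C)nn(C)c1Oc1cccc(F)c1`
compound 2 `Cc1nnsc1CO/N=C/c1c(C)nn(C)c1Oc1ccc(F)cc1`
compound 3 `Cc1nnsc1CO/N=C/c1c(C)nn(C)c1Oc1ccc(I)cc1`

In a functional assay on SGC-7901 cells (Homo sapiens) for inhibition, read by MTT assay, with a stated time of 48 h (on this read-out higher numbers stand for weaker inhibition and lower numbers for stronger inhibition), compound 1 reports only a limit, > 50000 nM. In this assay compound 2 likewise reports only a limit, > 50000 nM. In this assay compound 3 also reports only a limit, > 50000 nM.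

Compound 3 therefore stands at the limit of > 50000 nM in this assay, at which 3 of the 3 values shown sit, together with the two other measured compounds, and no order among the three can be read. The steps a step that the two limits leave unreadable from compound 1 to compound 2, a step that the two limits leave unreadable from compound 1 to compound 3 and a step that the two limits leave unreadable from compound 2 to compound 3 are all of unreadable size, and none of them sets any direction.

Compound 4 `Cc1nnsc1CO/N=C/c1c(C)nn(C)c1Cl` differs from compound 3 by chloro in place of 4-iodophenoxy on an aromatic carbon. No measured step touches this kind of change, and the measured steps that exist give no readable size, so no direction beyond the scatter can be stated from the numbers shown. Compound 4 is expected to report a limit again, with an estimate of 60000 nM and a range from 10000 nM to 300000 nM. The expected step is a step that the limit leaves unreadable from compound 3 to compound 4.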

Compound 4, half-maximal inhibitory concentration: > 50000 nM
Compound 4 was reported as a limit; the forecaster's own chance of this, stated with the estimate: 75%; the middle value is on the limit's open side.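

Compound 4 gives no readable step against compound 1, compound 2 or compound 3 in this assay and all four report only a limit: the limit of > 50000 nM in this assay, at which 4 of the 4 values shown sit. The compounds shown leave open how the four rank and which change to the shared core, if any, would give a measurable value.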